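The compounds below may be only part of what the source reports. "The series", "measured", "known", "first", "only" and "open" are said of these compounds alone.

In a functional assay (aorta) with Oryctolagus cuniculus as the target (on this read-out lower numbers stand for tighter binding and higher numbers for weaker binding), compound 1 (`COC(=O)c1ccc(OCCCN2CCC(C(c3ccc(F)cc3)c3ccc(F)cc3)CC2)c(OC)c1`) gives 1.26 nM and compound 2 (`COc1cc(C(=O)O)ccc1OCCCN1CCC(C(c2ccc(F)cc2)c2ccc(F)cc2)CC1`) gives 79.4 nM. Compound 3 (`CC(=O)c1ccc(OCCCN2CCC(C(c3ccc(F)cc3)c3ccc(F)cc3)CC2)cc1`) gives 2.51 nM and so lies within the scatter of compound 1 and well under compound 2.

Compound 4 (`CC(=O)Nc1ccc(OCCCN2CCC(C(c3ccc(F)cc3)c3ccc(F)cc3)CC2)cc1`) has acetamido in place of acetyl on an aromatic carbon of a six-membered aromatic ring of carbon only, para to a large group (acetamido in place of acetyl on an aromatic carbon). Among the measured compounds shown here, no measured step makes this exact exchange.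

For the measured compounds named here, the nearest precedent is the exchange of aryl groups in the step of a 2.0-fold higher number from compound 1 to compound 3 (0.30 log units; within the scatter) which stayed within the scatter. The two large steps, a 63-fold higher number from compound 1 to compound 2 (1.80 log units; beyond the scatter) and a 32-fold lower number from compound 2 to compound 3 (1.50 log units; beyond the scatter) both involve the carboxy group of compound 2, and neither acetyl nor acetamido is a carboxy group. They therefore offer little guidance here.

No step beyond the scatter is expected in this assay and any drift is expected to be slightly upward. The expected step is a 1.6-fold higher number from compound 3 to compound 4 (0.20 log units; within the scatter) on this evidence. Compound 4 is estimated at 4 nM with an expected range of 1 nM to 16 nM on this read-out.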

Compound 4, dissociation constant: 12.6 nM
Compound 4: the middle estimate sits 3.2-fold (0.50 log units) below what was measured; the measured number falls inside the stated range.
By their numbers in this assay, from the lowest: compounds 1 and 3 (each within the scatter of the next); then compound 4; then compound 2.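

In this assay this place, on an aromatic carbon para to a large group, does not tolerate every exchange: acetamido in place of acetyl, which adds a nitrogen and a hydrogen-bond donor, gives a 5.0-fold higher number from compound 3 to compound 4 (0.70 log units; beyond the scatter). The earlier large steps all involved the carboxy group of compound 2, whereas this step beyond the scatter arises with no carboxy group in either compound. Compound 4 also stands apart from both earlier reference points, with a 10-fold higher number from compound 1 to compound 4 (1.00 log units; beyond the scatter) and a 6.3-fold lower number from compound 2 to compound 4 (0.80 log units; beyond the scatter), and nothing available here accounts for the shift.

From the compounds shown here alone, whether the step follows the amide hydrogen remains open, and a methyl group on the amide nitrogen would address that. Going by these compounds, it is also open whether a methanesulfonamido group or a primary amine at this place would stay closer to compound 3 or to compound 4.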